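From a methyl to a hydrogen on compound 2

This account rests on a few compounds, and the source may have more. Where it says the series, first, only, none or still open, it means among the compounds named here.

In a functional assay on MCF7 cells (Homo sapiens) for cytotoxicity, read by MTT assay, with a stated time of 48 h (a higher number here means a weaker inhibitor, a lower number a stronger inhibitor), compound 2 (`Cc1ccc(C(C2c3onc(C)c3N=C(c3ccccc3)CC2c2ccccc2)C2c3onc(C)c3N=C(c3ccccc3)CC2c2ccccc2)cc1`) gives 41.9 ug/mL. That value lies within the usual scatter of the other two measured compounds: compound 3 (`COc1ccc(C(C2c3onc(C)c3N=C(c3ccccc3)CC2c2ccccc2)C2c3onc(C)c3N=C(c3ccccc3)CC2c2ccccc2)cc1`) gives 57.3 ug/mL and compound 1 (`Cc1noc2c1N=C(c1cccs1)CC(c1ccccc1)C2C(c1ccccc1)C1c2onc(C)c2N=C(c2cccs2)CC1c1ccccc1`) gives 24.1 ug/mL. These three numbers therefore cannot be ranked with confidence.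

Compound 4 (`Cc1noc2c1N=C(c1ccccc1)CC(c1ccccc1)C2C(c1ccccc1)C1c2onc(C)c2N=C(c2ccccc2)CC1c1ccccc1`) has not yet been measured. It differs from compound 2 by one change, hydrogen in place of methyl on an aromatic carbon, turning 4-methylphenyl into phenyl: hydrogen in place of methyl on an aromatic carbon. For the measured compounds named here, the one measured step at this same place is methoxy in place of methyl, which gave a 1.4-fold higher number from compound 2 to compound 3 (0.14 log units; within the scatter). Compound 1 also lacks a group there, although it differs elsewhere. This small step points to no clear direction, so no change beyond the scatter is expected in this assay. The expected result is a 1.1-fold lower number from compound 2 to compound 4 (0.04 log units; within the scatter). The estimated value for compound 4 is 38 ug/mL, with an expected range of 21 ug/mL to 70 ug/mL.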

Compound 4, half-maximal inhibitory concentration: 68.9 ug/mL
Compound 4: the middle estimate sits 1.8-fold (0.26 log units) below what was measured; low and high end bracket the measured number.
By their numbers in this assay, from the lowest: compounds 1, 2, 3 and 4 (each within the scatter of the next, the first and the last beyond it).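

In this assay the change from 4-methylphenyl to phenyl gives a 1.6-fold higher number from compound 2 to compound 4 (0.22 log units; within the scatter) and hydrogen in place of methoxy gives a 1.2-fold higher number from compound 3 to compound 4 (0.08 log units; within the scatter) on the same aromatic carbon. For the compounds shown here, the earlier pair showed only that one group could replace another at this place, whereas these steps show that removing the group altogether also leaves the number within the scatter. Among methyl, methoxy and hydrogen on this carbon, no single swap has yet produced a readable change, and no measurement on hand speaks to what lies behind these numbers.

As far as these compounds go, whether an amine, a carboxylic acid or a longer chain on this carbon would move the number beyond the scatter remains open. Also open, from the compounds shown here alone, is whether these small steps would hold on a different core, since compounds 2, 3 and 4 share a single one.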